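Ethyl to isopropyl: one more methyl on the amide

This account rests on a few compounds, and the source may have more. Where it says the series, first, only, none or still open, it means among the compounds named here.

In a functional assay on U-937 cells (Homo sapiens) for cytotoxicity, read by MTT assay, with a stated time of 48 h (a higher number here means a weaker inhibitor, a lower number a stronger inhibitor), compound 1 (`NC(=O)CC[C@H](NS(=O)(=O)c1ccc([N+](=O)[O-])cc1)C(=O)O`) gives > 500000 nM here, which is a limit and not a number. Compound 2 (`CNC(=O)CC[C@H](NS(=O)(=O)c1ccc([N+](=O)[O-])cc1)C(=O)O`) gives > 500000 nM here, also a limit. For the measured compounds named here, compound 3 (`CCNC(=O)CC[C@H](NS(=O)(=O)c1ccc([N+](=O)[O-])cc1)C(=O)O`) gives 89400 nM as the only true number so far. Compound 4 (`CC(C)NC(=O)CC[C@H](NS(=O)(=O)c1ccc([N+](=O)[O-])cc1)C(=O)O`) differs from it by methyl in place of hydrogen on a saturated chain carbon bound to an amide-type nitrogen and a saturated chain carbon and amounts to ethyl becoming isopropyl. The closest measured change, also methyl in place of hydrogen on a saturated chain carbon bound to an amide-type nitrogen, is an at least 5.5-fold lower number from compound 2 to compound 3 (0.74 log units; beyond the scatter) and an at least 5.5-fold lower number from compound 1 to compound 3 (0.74 log units; beyond the scatter) points the same way. As far as these compounds go, both begin at a limit, so their true sizes remain open. A further modest lowering is expected, namely a 2.2-fold lower number from compound 3 to compound 4 (0.35 log units; beyond the scatter) in this assay as the estimated step. For compound 4 the estimated value is 40000 nM with an expected range from 15000 nM to 120000 nM overall.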

Compound 4, half-maximal inhibitory concentration: 95100 nM
Compound 4: middle estimate off by 2.4-fold (0.38 log units), on the low side, within the range that was stated.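

In this assay, the methyl that turns ethyl into isopropyl leaves a 1.1-fold higher number from compound 3 to compound 4 (0.03 log units; within the scatter), so the drop in the number seen on reaching ethyl does not carry on at this carbon. Against the two smaller amides, compound 4 shows an at least 5.2-fold lower number from compound 2 to compound 4 (0.72 log units; beyond the scatter) and an at least 5.2-fold lower number from compound 1 to compound 4 (0.72 log units; beyond the scatter), much as compound 3 does. As far as these compounds go, both of these steps start from a limit, so their true sizes stay open: the limit of > 500000 nM in this assay, at which 2 of the 4 values shown sit.

From the compounds shown here alone, whether a longer chain such as butyl, or a benzyl group, on the amide-type nitrogen would lower the number further remains open.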